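The source may report more compounds than this note shows. Statements on the series, on what has been measured and on what is new or still open speak of the compounds shown alone.

Series notes, maximal electroshock read-out:

compound 1, `CCC(C(=O)N1CCN(c2ccccc2)CC1)N1C(=O)CCC1=O`: 25%
compound 2, `CCC(C(=O)N1CCN(c2cccc(OC)c2)CC1)N1C(=O)CCC1=O`: 0%
compound 3, `CCC(C(=O)N1CCN(c2cccc(C)c2)CC1)N1C(=O)CCC1=O`: 0%

All three numbers come from a functional assay on the whole organism (strain Swiss) with Mus musculus as the target, in the maximal electroshock model, with a stated time of 2 h, at a dose of 300 mg/kg by the intraperitoneal route; on this read-out higher numbers stand for a stronger effect at the one dose given and lower numbers for a weaker effect. Compound 3 stands at the same level as compound 2 at the digits reported; the two together form the lower of the two levels seen, and only compound 1 stands apart from them. The steps are: a number 25 percentage points lower from compound 1 to compound 3 (beyond the scatter) and, in the same way, a number 25 percentage points lower from compound 1 to compound 2 (beyond the scatter); between the two substituted compounds there is no change at the digits printed from compound 2 to compound 3 (within the scatter).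

The next compound is compound 4, `CCC(C(=O)N1CCN(c2cccc(C(F)(F)F)c2)CC1)N1C(=O)CCC1=O`. Relative to compound 3 the change is trifluoromethyl in place of methyl on an aromatic carbon. Going by the values given here, no measured step has a trifluoromethyl in it, so the bearing is indirect. Two steps speak to this position on the ring: the drop a number 25 percentage points lower from compound 1 to compound 3 (beyond the scatter) shows that putting a group there took the activity to the floor, and no change at the digits printed from compound 2 to compound 3 (within the scatter) shows that exchanging one such group for another left the number where it was. With the starting value already at the floor, the expected step is none beyond the scatter, a number 5 percentage points higher from compound 3 to compound 4 (within the scatter). For compound 4 the estimate in this assay is 5%, with a range from 0% to 25%.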

Compound 4, a percentage reported as activity, at one dose (the size of the read-out at that dose, not a potency): 50%
Estimate against measurement, compound 4: 45 percentage points below; measured number above the stated range.
By their numbers in this assay, from the lowest: compounds 2 and 3 (each within the scatter of the next); then compound 1; then compound 4.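

In this assay this aromatic carbon proves not to be a dead end for every group: the step of a number 50 percentage points higher from compound 3 to compound 4 (beyond the scatter) and the step of a number 50 percentage points higher from compound 2 to compound 4 (beyond the scatter) both lie beyond the scatter, so the earlier match between methyl and methoxy does not extend to trifluoromethyl. The step of a number 25 percentage points higher from compound 1 to compound 4 (beyond the scatter) adds that a group at this place, meta to a large group, can also lift the number above that of the unsubstituted compound, so substitution here has no single direction, with compound 2 and compound 3 going against any rule that it helps and compound 4 against any rule that it harms. Nothing measured in this set bears on why trifluoromethyl parts from methyl and methoxy.

Going by these compounds, whether a chlorine, a nitrile or an amine on this same aromatic carbon would sit with compound 4 or with compound 2 and compound 3 remains open, so three groups at one place do not yet define a trend. Also open, on these data alone, is whether trifluoromethyl elsewhere on the ring would give a similar number, and whether the order seen at this single dose and time would hold at others.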